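The source may hold more compounds than are shown below. What is called first, only, known or untested is meant among the compounds shown, and "the series" means these compounds.

Two measured compounds share a core in which an aryloxy group is attached through an oxygen. Compound 1, `Cc1ccccc1Oc1ccc(CC2SC(=O)NC2=O)cc1`, gives 124 nM in a functional assay for agonist activity at Free fatty acid receptor 1 (Homo sapiens), read by FLIPR, in the presence of a further agent that is not named here; a lower number here means that less compound is needed, a higher number that more compound is needed for the effect. Compound 2, `Cc1cccnc1Oc1ccc(CC2SC(=O)NC2=O)cc1`, gives 1090 nM in this assay and so stands as the higher of the two numbers, the step being an 8.8-fold higher number from compound 1 to compound 2 (0.94 log units; beyond the scatter). Compound 3, `O=C1NC(=O)C(Cc2ccc(Oc3ncccc3C(F)(F)F)cc2)S1`, has not yet been measured. It differs from compound 2 only in one place: trifluoromethyl in place of methyl on an aromatic carbon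

Among the measured compounds shown here, no measured step concerns this change. For the measured compounds named here, the single step in the set, an 8.8-fold higher number from compound 1 to compound 2 (0.94 log units; beyond the scatter), exchanges the whole aryl ring rather than the group on it, and so says little about how replacing the methyl with a trifluoromethyl on the ring with one nitrogen would move the number. Without a comparable pair, the expectation for compound 3 in this assay is a step of no great size in either direction, most likely within or only just beyond the scatter, with a wide range to cover the lack of precedent. Compound 3 is therefore expected to give about 900 nM, between 300 nM and 3000 nM, a step of a 1.2-fold lower number from compound 2 to compound 3 (0.08 log units; within the scatter) that is estimated rather than known.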

Compound 3, half-maximal effective concentration: 2290 nM
Beside the measured number, compound 3's estimate is 2.5-fold (0.41 log units) below it; the measured number falls inside the stated range.
By their numbers in this assay, from the lowest: compound 1; then compound 2; then compound 3.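

On the six-membered aromatic ring with 1 nitrogen, the aromatic carbon ortho to a large group and two atoms from the ring nitrogen now has a measured step of its own: in this assay, trifluoromethyl in place of methyl gives a 2.1-fold higher number from compound 2 to compound 3 (0.32 log units; beyond the scatter), a modest change printed as beyond the scatter. This shows that the number responds to the group at this position, and that here trifluoromethyl, with its four heavy atoms against the single one of methyl, does not lower it, which the earlier step could not show since it exchanged the aryl ring and kept the methyl. Nothing measured in this set accounts for the direction or size of the step.

On these data alone, whether the number tracks the size of the group at this position stays open, and a chlorine atom, a methoxy group, a nitrile or a plain hydrogen in the same place would give further points for judging that. Also open, as far as these compounds go, is whether the same exchange on the 2-methylphenyl ring of compound 1 would give a step of similar size and direction.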